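Straightening the Amine Chain: Compound 4 in Kinetic Solubility

The compounds below may be only part of what the source reports. "The series", "measured", "known", "first", "only" and "open" are said of these compounds alone.

compound 1 `c1cc([C@H]2CC[C@]3(CC2)OOC2(O3)C3CC4CC(C3)CC2C4)ccc1OCC1CCNCC1`: 12.5 ug/mL
compound 2 `CC(C)(CN)Oc1ccc([C@H]2CC[C@]3(CC2)OOC2(O3)C3CC4CC(C3)CC2C4)cc1`: > 100 ug/mL
compound 3 `CC(C)(N)CCOc1ccc([C@H]2CC[C@]3(CC2)OOC2(O3)C3CC4CC(C3)CC2C4)cc1`: 50 ug/mL

Compound 2 stands at the top of the three values in a physicochemical assay for solubility, read by nephelometry, measured as kinetic solubility, with a stated time of 30 min; on this read-out lower numbers stand for lower solubility and higher numbers for higher solubility. In this assay compound 2 gives > 100 ug/mL, which is a limit of the assay and not a number, as the limit of > 100 ug/mL in this assay, at which 1 of the 3 values shown sits, records. Compound 4 `NCCCCOc1ccc([C@H]2CC[C@]3(CC2)OOC2(O3)C3CC4CC(C3)CC2C4)cc1` has the same atoms as compound 2, joined differently: 4-aminobutyl in place of 1-(aminomethyl)-1-methylethyl on an oxygen on an aromatic ring.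

Going by the values given here, two measured steps bear on this change. The step of an at least 8.0-fold higher number from compound 1 to compound 2 (0.90 log units; beyond the scatter) shows that replacing the ring-bearing side chain of compound 1 with an open amine chain raised the number beyond the scatter. The step of an at least 2.0-fold lower number from compound 2 to compound 3 (0.30 log units; that floor lies within the scatter), which also keeps an open amine chain on the oxygen, gives only a floor that lies within the scatter. Compound 4 keeps an open chain and the same donor and acceptor count, so no step beyond the scatter is expected, though a result at or near the limit remains possible; the expected step is an at least 1.4-fold lower number from compound 2 to compound 4 (0.15 log units; that floor lies within the scatter). Compound 4 is therefore estimated at 70 ug/mL, within a range of 30 ug/mL to 100 ug/mL.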

Compound 4, solubility: 50 ug/mL
For compound 4 the middle estimate is 1.4-fold (0.15 log units) above the measured one, within the range that was stated.
By their numbers in this assay, from the lowest: compound 1; then compounds 3 and 4 (each within the scatter of the next). At a limit, above all of these: compound 2.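

In this assay, the change from 1-(aminomethyl)-1-methylethyl to 4-aminobutyl on the oxygen gives only a floor, an at least 2.0-fold lower number from compound 2 to compound 4 (0.30 log units; that floor lies within the scatter), and this step cannot show how far apart the two chains truly stand. Compound 2 is held at a limit of the assay, not at a number: the limit of > 100 ug/mL in this assay, at which 1 of the 4 values shown sits.

What compound 4 adds is a third open amine chain that stands clear of the piperidin-4-yl side chain, a 4.0-fold higher number from compound 1 to compound 4 (0.60 log units; beyond the scatter), while the 2-aminoethyl and 1-amino-1-methylethyl ends show no change at the digits printed from compound 3 to compound 4 (within the scatter).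

The compounds shown leave open how a 4-aminobutyl chain compares with a longer or shorter amine chain in this assay. They also leave open what a dimethylamino group or a carboxylic acid at the chain end would read there.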